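The source may report more compounds than this note shows. Statements on the series, on what has been measured and on what is new or still open speak of the compounds shown alone.

In a functional assay on DU-145 cells (Homo sapiens) for inhibition, read by trypan blue exclusion, with a stated time of 96 h (a higher number here means a weaker inhibitor of growth, a lower number a stronger inhibitor of growth), compound 1 (`Cc1ccc(C)c(/C=C(/Sc2ccc(Br)cc2)C(=O)c2ccc(Cl)cc2)c1`) gives 10000 nM and compound 2 (`COc1ccc(/C=C(/SCc2ccc(Cl)cc2)C(=O)c2ccc(Cl)cc2)cc1`) gives 10000 nM. Compound 2 therefore stands level with compound 1, and the two values offer no separation between them. Compound 3 (`COc1ccc(/C=C(/Sc2ccc(Br)cc2)C(=O)c2ccc(Cl)cc2)cc1`) has not yet been measured. It departs from compound 2 at one place, on a sulfur whose other neighbour is a double-bonded chain carbon: 4-bromophenyl in place of 4-chlorobenzyl on a sulfur. In words, 4-bromophenyl takes the place of 4-chlorobenzyl on a sulfur. Within the data shown here, no measured pair shows this change on its own, so the expectation rests on little. Compound 1 already carries the (4-bromophenyl)sulfanyl group and gives 10000 nM, so that group alone gives no reason to expect a large gain, although compound 1 also differs from compound 3 elsewhere. A small move toward stronger growth inhibition in this assay is expected, but nothing beyond the scatter. The expected step is a 1.7-fold lower number from compound 2 to compound 3 (0.22 log units; within the scatter). For compound 3 the estimated value is 6000 nM, with an expected range from 1000 nM to 15000 nM.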

Compound 3, concentration for 50% growth inhibition: 50000 nM
Beside the measured number, compound 3's estimate is 8.3-fold (0.92 log units) below it, outside the stated range (above it).
By their numbers in this assay, from the lowest: compounds 1 and 2 (each within the scatter of the next); then compound 3.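

In this assay, among these compounds, the single change of 4-bromophenyl in place of 4-chlorobenzyl on a sulfur gives a 5.0-fold higher number from compound 2 to compound 3 (0.70 log units; beyond the scatter), which shows that the group on this sulfur affects the read-out when the 4-methoxyphenyl group stays in place. The other single change, 4-methoxyphenyl in place of 2,5-dimethylphenyl on a double-bonded chain carbon bound to a double-bonded chain carbon, gives a 5.0-fold higher number from compound 1 to compound 3 (0.70 log units; beyond the scatter), so the number reached with the (4-bromophenyl)sulfanyl group also depends on what sits at that second place. No measurement shown explains either step.

The step on the sulfur swaps the benzyl for the phenyl attachment and the chlorine for the bromine at once, and a 4-chlorophenyl or a 4-bromobenzyl group on the sulfur would be needed to tell those two parts apart. The compounds shown also leave open whether an amine or a carboxylic acid on the sulfur would bring the number lower than the value of compound 2, 10000 nM, in this assay.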